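This account rests on a few compounds, and the source may have more. Where it says the series, first, only, none or still open, it means among the compounds named here.

Working notes on the series built on the core of compound 1 `CC(=O)SCC(=O)c1ccc(NS(=O)(=O)c2ccc(OCCc3ccccn3)cc2)nc1`, in which the group on an oxygen on an aromatic ring is varied. In a functional assay on U226 cells (Homo sapiens) for cytotoxicity (a lower number here means that less compound is needed, a higher number that more compound is needed for the effect), compound 1 gives 9600 nM. Compound 2 `CC(=O)SCC(=O)c1ccc(NS(=O)(=O)c2ccc(OC3CCCN(C)C3)cc2)nc1` gives 1200 nM, reached by an 8.0-fold lower number from compound 1 to compound 2 (0.90 log units; beyond the scatter) on exchanging 2-(pyridin-2-yl)ethyl for 1-methylpiperidin-3-yl. Compound 3 `CC(=O)SCC(=O)c1ccc(NS(=O)(=O)c2ccc(OCCCO)cc2)nc1` gives "not determined" (no result reported) in this assay. Among the numbers present, compound 2 thus stands lowest, with compound 1 as the only comparator and that gap beyond the scatter.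

Compound 4 `CC(=O)SCC(=O)c1ccc(NS(=O)(=O)c2ccc(OC3CCN(C)CC3)cc2)nc1` is the next entry; its difference from compound 2 is 1-methylpiperidin-4-yl in place of 1-methylpiperidin-3-yl on an oxygen on an aromatic ring. For the measured compounds named here, no measured step bears directly on this change: the single step available, an 8.0-fold lower number from compound 1 to compound 2 (0.90 log units; beyond the scatter), exchanges a group of a different kind and gives no guidance on rearranging the same atoms within 1-methylpiperidinyl. For compound 4 the expected step of no change at the digits printed from compound 2 to compound 4 (within the scatter) is therefore none beyond the scatter. Compound 4 is accordingly estimated at 1200 nM, within a range of 400 nM to 3600 nM.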

Compound 4, half-maximal effective concentration: 300 nM
The estimate for compound 4 lay 4.0-fold (0.60 log units) above the measured number, outside the stated range (below it).
By their numbers in this assay, from the lowest: compound 4; then compound 2; then compound 1.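

In this assay, exchanging 1-methylpiperidin-3-yl for 1-methylpiperidin-4-yl, with the same atoms joined differently, gives a 4.0-fold lower number from compound 2 to compound 4 (0.60 log units; beyond the scatter) and so shows that the read-out at this position responds to how the ring is joined to the oxygen, not only to which atoms are present. The lowest number in the series now belongs to the 1-methylpiperidin-4-yl group, and the span across the series widens to a 32-fold lower number from compound 1 to compound 4 (1.51 log units; beyond the scatter). Nothing available explains why the two ring attachments differ.

Still open, going by these compounds, is whether the methyl on the ring nitrogen contributes to this result, which a piperidin-4-yl group with a free amine or an N-ethylpiperidin-4-yl group would test. On these data alone, it is equally open whether a ring is needed at all, or whether an open chain such as 2-(dimethylamino)ethyl would give a similar number.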